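Chloro entering the phenyl ring of compound 2

The source may report more compounds than this note shows. Statements on the series, on what has been measured and on what is new or still open speak of the compounds shown alone.

Two compounds of the series have been run in an assay on HEK293 cells for inhibition of Voltage-dependent T-type calcium channel subunit alpha-1G (Homo sapiens), read by patch clamp, tested at 10 uM; on this read-out higher numbers stand for more inhibition at the one concentration tested (going by the name of the read-out) and lower numbers for less inhibition. Compound 1 `O=C(CCCCN1CCN(c2cccc(Cl)c2)CC1)Nc1ccccc1Cl` gives 93.2%, and compound 2 `O=C(CCCN1CCN(c2ccccc2)CC1)Nc1ccc(Cl)cc1` gives 75.1%. Going by the values given here, compound 2 stands lowest of the two numbers, with compound 1 above it by a margin beyond the scatter; the two differ in more than one place, so no single step is read between them. Compound 3 `O=C(CCCN1CCN(c2ccccc2Cl)CC1)Nc1ccc(Cl)cc1` is compound 2 with one change: chloro in place of hydrogen on an aromatic carbon. Cut one bond further out, the change reads phenyl to 2-chlorophenyl, ortho to a large group. Among the compounds with values here, no measured pair isolates that change. Compound 1, which also carries chloro on that ring, reads higher than compound 2, but other differences accompany it. A moderate rise in this assay is expected, near the edge of the scatter, as a number 7.9 percentage points higher from compound 2 to compound 3 (within the scatter). Compound 3 is expected to give 83%, within the range 66% to 96%.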

Compound 3, a percentage reported as inhibition, at one concentration (the size of the read-out at that concentration, not a potency): 60.5%
Beside the measured number, compound 3's estimate is 22.5 percentage points above it; measured number outside the range, below it.
By their numbers in this assay, from the lowest: compound 3; then compound 2; then compound 1.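

In this assay, going by these compounds alone, the step for chloro in place of hydrogen on an aromatic carbon, ortho to a large group, reads a number 14.6 percentage points lower from compound 2 to compound 3 (beyond the scatter) and is the first single change that can be read on its own. At this position, phenyl to 2-chlorophenyl therefore lowers inhibition at the one concentration tested, although a modest part of the read-out remains. No evidence at hand bears on the origin of this drop.

On these data alone, whether the loss belongs to chloro itself or to any group at this position stays open; fluoro, methyl or methoxy on the same carbon would separate those readings. Also open, as far as these compounds go, is whether the same step holds on the core of compound 1, which has a longer chain and differs in other places.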